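The source may report more compounds than this note shows. Statements on the series, on what has been measured and on what is new or still open speak of the compounds shown alone.

Measured compounds:
compound 1, `CNCc1cn(S(=O)(=O)c2ccoc2)c(-c2cccnc2F)c1F` — in a functional assay on the whole organism (strain Jcl:Sprague-Dawley) for inhibition, with Rattus norvegicus as the target, with stated times of 3 min and 3 h, at a dose of 1 mg/kg by the intravenous route (a lower number here means less inhibition, a higher number more inhibition at the dose given (going by the name of the read-out)), compound 1 gives 95%
compound 2, `CNCc1cn(S(=O)(=O)c2ccc(OC)cn2)c(-c2cccnc2F)c1F` — in this assay compound 2 gives 95%
compound 3, `CNCc1cn(S(=O)(=O)c2cccc(F)n2)c(-c2cccnc2F)c1F` — in this assay compound 3 stands at "not determined" (no result reported)

For the measured compounds named here, compound 3 therefore has no number in this assay; its position cannot be read from the data, and no measured step touches it. The move followed here goes from compound 3 to compound 4, `CNCc1cn(S(=O)(=O)c2cnccc2C)c(-c2cccnc2F)c1F`. The difference between the two structures is 4-methylpyridin-3-yl in place of 6-fluoropyridin-2-yl on a sulfonyl sulfur.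

Going by the values given here, the only measured step that exchanges the group on the sulfonyl sulfur is no change at the digits printed from compound 1 to compound 2 (within the scatter). Among the compounds with values here, both compounds there sit near the top of the read-out scale, so that step shows only that one such exchange left the inhibition where it was; it does not involve either of the groups exchanged here and so bears on the present change only loosely. Nothing measured points to a fall in this assay, and the read-out is already close to its ceiling for the two compounds that carry a number, so no step beyond the scatter is expected.

Compound 4 is expected to give 90% in this assay, estimated between 70% and 100%.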

Compound 4, a percentage reported as inhibition, in the whole organism at one dose (the size of the read-out at that dose, not a potency): 98%
Compound 4: the middle estimate sits 8 percentage points below what was measured, and the stated range covers the measured number.
By their numbers in this assay, from the lowest: compounds 1, 2 and 4 (each within the scatter of the next).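

The step from compound 3 cannot be read, compound 3 carrying no number in this assay, so what compound 4 adds comes from its steps to the other two compounds: a number 3 percentage points higher from compound 2 to compound 4 (within the scatter) and a number 3 percentage points higher from compound 1 to compound 4 (within the scatter). Along with furan-3-yl and 5-methoxypyridin-2-yl, 4-methylpyridin-3-yl is now a third group on a sulfonyl sulfur whose other neighbour is aromatic nitrogen that leaves the read-out near the top of its scale, and at this single dose the three groups are not separated from one another. Nothing available speaks to why the read-out holds across these groups.

Going by these compounds, whether this holds for groups of another kind on the sulfonyl sulfur, such as a simple alkyl chain or a phenyl ring carrying a carboxylic acid, stays open. Also open, on these data alone, are the place of compound 3 in the series and any difference in potency among compound 1, compound 2 and compound 4, a read-out at one dose near the top of the scale not being a potency.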